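The source may hold more compounds than are shown below. What is called first, only, known or untested is meant among the compounds shown, and "the series" means these compounds.

In a functional assay on HEK293 cells (Homo sapiens) for cytotoxicity (on this read-out higher numbers stand for lower toxicity in this test and lower numbers for higher toxicity in this test), compound 1 `COc1ccc([C@H]2CC(=O)N(C(C)=O)C2)cc1OC1CCCC1` gives > 10000 nM, which is a limit and not a number. Compound 2 `COc1ccc([C@H]2CC(=O)N(c3ccccc3C)C2)cc1OC1CCCC1` gives > 10000 nM, which is likewise a limit. Compound 2 therefore has no exact position on the scale, and the record so far is the limit of > 10000 nM in this assay, at which 2 of the 2 values shown sit.

Compound 3 `COc1ccc([C@H]2CC(=O)N(c3cccc(C)c3)C2)cc1OC1CCCC1` keeps the shared core and carries 3-methylphenyl in place of 2-methylphenyl on an amide-type nitrogen in a ring. The two groups have the same atoms, joined differently: 3-methylphenyl in place of 2-methylphenyl on an amide-type nitrogen in a ring.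

Among the compounds with values here, the only measured step that bears on this change is a step that the two limits leave unreadable from compound 1 to compound 2. Within the data shown here, it introduced the 2-methylphenyl group, but it offers no size to carry forward, and no measured step covers a change from 2-methylphenyl to 3-methylphenyl. On this thin basis, no step beyond the scatter is expected in this assay, and no direction can be assigned. The expected step is a step that the limit leaves unreadable from compound 2 to compound 3. Compound 3 is estimated at 15000 nM, with an expected range of 7000 nM to 40000 nM, and a further report as a limit is the likeliest outcome.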

Compound 3, half-maximal cytotoxic concentration: > 10000 nM
Compound 3: only a limit was reported; the forecaster's own chance of this, stated with the estimate: 85%; the middle value lies beyond the limit too.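

In this assay compound 3 gives > 10000 nM, which is a limit and not a number. Within the data shown here, no step among compound 1, compound 2 and compound 3 can therefore be read. These compounds leave open whether acetyl, 2-methylphenyl and 3-methylphenyl on the amide-type nitrogen differ at all in half-maximal cytotoxic concentration, the record being: the limit of > 10000 nM in this assay, at which 3 of the 3 values shown sit.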